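The source may report more compounds than this note shows. Statements on the series, on what has been measured and on what is new or still open speak of the compounds shown alone.

Measured in an ADME assay on cells (Astrocyte, Rattus norvegicus, strain Wistar) for inhibition, read by sulforhodamine B assay, with a stated time of 72 h; a higher number here means that more compound is tolerated, a lower number that less compound is tolerated:
- compound 1 `O=C(/C=C/c1ccc([N+](=O)[O-])o1)c1ccc(I)cc1`: 68200 nM
- compound 2 `CSc1ccc(C(=O)/C=C/c2ccc([N+](=O)[O-])o2)cc1`: 28400 nM

For the measured compounds named here, compound 2, at 28400 nM, holds the lower of the two numbers, and compound 1 is its only neighbour. Compound 3 `CCCCc1ccc(C(=O)/C=C/c2ccc([N+](=O)[O-])o2)cc1` carries butyl in place of methylsulfanyl on an aromatic carbon. Going by the values given here, the one measured step, a 2.4-fold lower number from compound 1 to compound 2 (0.38 log units; beyond the scatter), also exchanges a group on an aromatic carbon and is modest. Among the compounds with values here, with only that guide, no step beyond the scatter is expected in this assay. The expected step is a 1.2-fold higher number from compound 2 to compound 3 (0.09 log units; within the scatter). For compound 3 the estimated value is 35000 nM, with an expected range of 13000 nM to 90000 nM.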

Compound 3, half-maximal cytotoxic concentration: 41200 nM
Beside the measured number, compound 3's estimate is 1.2-fold (0.07 log units) below it; measured number inside the range.
By their numbers in this assay, from the lowest: compounds 2, 3 and 1 (each within the scatter of the next, the first and the last beyond it).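

In this assay butyl on this aromatic carbon, para to a large group, gives a 1.5-fold higher number from compound 2 to compound 3 (0.16 log units; within the scatter) and a 1.7-fold lower number from compound 1 to compound 3 (0.22 log units; within the scatter) and so cannot be told apart from either methylsulfanyl or iodo, although those two groups lie beyond the scatter of each other. Exchanging methylsulfanyl for butyl, which has no hydrogen-bond acceptor, brings no step beyond the scatter. Nothing available here accounts for these numbers.

On these data alone, whether an amine, a carboxylic acid or a longer chain at this position would move the number beyond the scatter stays open. So does how far the shared core, rather than this group, sets the number.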